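Moving a methyl from one ring carbon to another

A few compounds are considered here, and "the series" means these few. Any claim that something is new, unique, unknown or untested is made for them only; others in the source may bear on it.

Compound 1 `O=C(Nc1cccc(/C=C/C(=O)c2nc3ccccc3[nH]2)c1)c1ccccc1` is one of three amides built on a shared core and tested in a functional assay on MCF7 cells (Homo sapiens) for antiproliferative activity, read by MTT assay, with a stated time of 48 h (on this read-out lower numbers stand for stronger inhibition and higher numbers for weaker inhibition), where compound 1 gives 11200 nM, the highest of the three numbers. Compound 2 `O=C(/C=C/c1cccc(NC(=O)c2ccccc2Cl)c1)c1nc2ccccc2[nH]1` gives 4570 nM, and compound 3 `Cc1ccccc1C(=O)Nc1cccc(/C=C/C(=O)c2nc3ccccc3[nH]2)c1` gives 5870 nM. The change to compound 4 `Cc1cccc(C(=O)Nc2cccc(/C=C/C(=O)c3nc4ccccc4[nH]3)c2)c1` is methyl in place of hydrogen on an aromatic carbon. For the measured compounds named here, two measured steps bear on it: a 1.9-fold lower number from compound 1 to compound 3 (0.28 log units; within the scatter), the same kind of change at a different place on the ring, and a 2.5-fold lower number from compound 1 to compound 2 (0.39 log units; beyond the scatter). Both run toward lower numbers, one within and one just beyond the scatter, so a small downward step, likely within the scatter, is expected, a 1.6-fold lower number from compound 1 to compound 4 (0.20 log units; within the scatter). Compound 4 is therefore estimated at 7000 nM, with a range from 3500 nM to 14000 nM.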

Compound 4, half-maximal inhibitory concentration: 5590 nM
Compound 4: the middle estimate sits 1.3-fold (0.10 log units) above what was measured; low and high end bracket the measured number.
By their numbers in this assay, from the lowest: compounds 2, 4, 3 and 1 (each within the scatter of the next, the first and the last beyond it).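

Placing a methyl on this ring carbon gives a 2.0-fold lower number from compound 1 to compound 4 (0.30 log units; within the scatter) and so stays inside the scatter, though only just. Moving the methyl from the other ring carbon gives a 1.1-fold lower number from compound 3 to compound 4 (0.02 log units; within the scatter), and swapping 2-chlorophenyl for 3-methylphenyl gives a 1.2-fold higher number from compound 2 to compound 4 (0.09 log units; within the scatter), so neither the methyl's place nor this swap separates these compounds. Nothing shown explains these numbers.

Going by these compounds, it remains open whether chloro on this same carbon would behave as methyl does here. On these data alone, it is also open whether an amine or a carboxylic acid there would shift the number beyond the scatter.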